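Working notes: hydrogen in place of ethyl, compound 4

The source may hold more compounds than are shown below. What is called first, only, known or untested is meant among the compounds shown, and "the series" means these compounds.

Compound 1 `CCc1ccccc1NC(=O)C1C(C(=O)O)[C@@H]2CC[C@H]1O2`, compound 2 `CCOC(=O)c1cn[nH]c1NC(=O)C1C(C(=O)O)[C@@H]2CC[C@H]1O2` and compound 3 `O=C(O)C1C(C(=O)NCCCc2ccccc2)[C@H]2CC[C@@H]1O2` share one core and differ only in the group carried on the amide nitrogen. In an ADME assay on HT-29 cells (Homo sapiens) for cytotoxicity, read by MTT assay, with a stated time of 72 h (a lower number here means a stronger inhibitor of growth, a higher number a weaker inhibitor of growth), compound 1 gives 10000 nM. In this assay compound 2 gives 10000 nM, and in this assay compound 3 gives 10000 nM. Compound 1 therefore stands level with compound 2 and compound 3 at the digits reported; the spread among the three lies within the usual scatter of the assay, so none of them is set apart from the others on these numbers.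

Compound 4 `O=C(O)C1C(C(=O)Nc2ccccc2)[C@H]2CC[C@@H]1O2` has not yet been measured. It differs from compound 1 by hydrogen in place of ethyl on an aromatic carbon. Among the measured compounds shown here, no step between two measured compounds of the set has been worked out, so the size of this change has no direct precedent here. What the three measured values do show is that the readings in this assay sit together across different amide substituents, and compound 4 keeps the aromatic ring of compound 1. No step beyond the scatter is expected in this assay for this change. For compound 4 the expected value in this assay is 10000 nM, with a range from 5000 nM to 20000 nM. The step of no change at the digits printed from compound 1 to compound 4 (within the scatter) is expected to stay within the scatter.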

Compound 4, concentration for 50% growth inhibition: 10000 nM
Compound 4: middle estimate and measured number agree at the digits printed; measured number inside the range.
By their numbers in this assay, from the lowest: compounds 1, 2, 3 and 4 (each within the scatter of the next).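

Compounds 1 and 4 give the series its first step between measured compounds that differ in one place: in this assay, hydrogen in place of ethyl on an aromatic carbon, ortho to a large group, gives no change at the digits printed from compound 1 to compound 4 (within the scatter). Until now, the matching readings came only from compounds with wholly different groups on the amide nitrogen, so they could not isolate any single change; here the ethyl group, with its 2 heavy atoms, can be removed from this position without a step beyond the scatter in this reading. No measurement on hand bears on the reason for this result.

The compounds shown leave open whether an amine, a carboxylic acid or a longer chain such as butyl on this same aromatic carbon would give a step beyond the scatter in this assay. They also leave open whether a group such as an amine or a methoxy group would give the same result at another carbon of the aromatic ring.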